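Shortening the Chain: What to Expect of Compound 4

The source may report more compounds than this note shows. Statements on the series, on what has been measured and on what is new or still open speak of the compounds shown alone.

Compound 1 `COc1cc(Nc2nc(N[C@H]3CC[C@H](N)CC3)nc3c2ncn3CCC(C)C)cc(OC)c1`: 140 nM
Compound 2 `CCCCCCn1cnc2c(Nc3cc(OC)cc(OC)c3)nc(N[C@H]3CC[C@H](N)CC3)nc21`: 380 nM
Compound 3 `CCCCCCn1cnc2c(Nc3cccc(Cl)c3)nc(N[C@H]3CC[C@H](N)CC3)nc21`: 310 nM

All three were measured in a functional assay on EOL1 cells (Homo sapiens) for inhibition, read by fluorescence, with a stated time of 72 h; a higher number here means a weaker inhibitor of growth, a lower number a stronger inhibitor of growth. Compound 2 and compound 3 share the same chain and differ only in the group on the ring nitrogen: 3-chlorophenyl in place of 3,5-dimethoxyphenyl on a nitrogen on an aromatic ring. That difference barely registers, since a 1.2-fold lower number from compound 2 to compound 3 (0.09 log units; within the scatter). Compound 1 and compound 2 share the 3,5-dimethoxyphenyl group and differ only in the chain: isopropyl in place of butyl on a saturated chain carbon, two bonds along the chain from an aromatic nitrogen. Here the step is larger, as a 2.7-fold lower number from compound 2 to compound 1 (0.43 log units; beyond the scatter).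

Compound 4 `CC(C)CCn1cnc2c(Nc3cccc(Cl)c3)nc(N[C@H]3CC[C@H](N)CC3)nc21` has not yet been measured. It stands to compound 3 exactly as compound 1 stands to compound 2, the same change in the same place: isopropyl in place of butyl on a saturated chain carbon, two bonds along the chain from an aromatic nitrogen. Within the data shown here, two compounds carry this change in all, and the one measured instance is the step from compound 2 to compound 1.

Given that the core difference between compound 2 and compound 3 hardly moved the number, it is reasonable to expect the chain change to carry over to the 3-chlorophenyl series with a similar size. The step from compound 3 to compound 4 is therefore expected to be a 2.5-fold lower number from compound 3 to compound 4 (0.39 log units; beyond the scatter), resting on the measured 2.7-fold lower number from compound 2 to compound 1 (0.43 log units; beyond the scatter). On that basis compound 4 is estimated at 125 nM, with a plausible range from 60 nM to 280 nM.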

Compound 4, concentration for 50% growth inhibition: 60 nM
Compound 4: the middle estimate sits 2.1-fold (0.32 log units) above what was measured; the measured number falls inside the stated range.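

In this assay, the swap of butyl for isopropyl on the chain gives a 5.2-fold lower number from compound 3 to compound 4 (0.71 log units; beyond the scatter), and it points the same way as the earlier step on the 3,5-dimethoxyphenyl compounds, with no real difference in size between the two: the same change on two cores in this assay, a 2.7-fold lower number (0.43 log units; beyond the scatter) from compound 2 to compound 1 and a 5.2-fold lower number (0.71 log units; beyond the scatter) from compound 3 to compound 4, 1.9-fold (0.28 log units) apart, within the scatter of two such steps

The aryl change tells a matching story, since moving from 3,5-dimethoxyphenyl to 3-chlorophenyl on the isopentyl chain gives a 2.3-fold lower number from compound 1 to compound 4 (0.37 log units; beyond the scatter), a step beyond the scatter where the same change on the hexyl chain stayed within it, yet the two steps cannot be told apart: the same change on two cores in this assay, a 1.2-fold lower number (0.09 log units; within the scatter) from compound 2 to compound 3 and a 2.3-fold lower number (0.37 log units; beyond the scatter) from compound 1 to compound 4, 1.9-fold (0.28 log units) apart, within the scatter of two such steps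

So in this small set each change carried from one core to the other, but this rests on a single pair of steps per change in one cell assay, and it shows neither why the numbers move nor that the steps would hold on any other core.

The compounds shown leave open how a shorter chain, a longer branched chain or a chain ending in an amine would behave in the same place. They also leave open whether the chain change would keep its effect with other groups on the nitrogen, such as a phenyl ring carrying a nitrile or a carboxylic acid.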